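Methyl in place of methoxy on an aromatic carbon

The source may hold more compounds than are shown below. What is called first, only, known or untested is meant among the compounds shown, and "the series" means these compounds.

Working values in a physicochemical assay for lipophilicity; a higher number here means a more lipophilic compound, a lower number a more polar compound:
- Compound 1 `C[C@H]1CC[C@@H]2[C@@H](OC(=O)[C@]23CC(c2ccc(C#N)cc2)N(c2ccccc2)O3)[C@]2(C)C(=O)C=C[C@@]12O`: 2.94
- Compound 2 `COc1ccc(C2C[C@@]3(ON2c2ccccc2)C(=O)O[C@@H]2[C@H]3CC[C@H](C)[C@]3(O)C=CC(=O)[C@@]23C)cc1`: 3.25

Of these two measured compounds, compound 2 stands highest in this assay, at 3.25. The next compound, compound 3 `Cc1ccc(C2C[C@@]3(ON2c2ccccc2)C(=O)O[C@@H]2[C@H]3CC[C@H](C)[C@]3(O)C=CC(=O)[C@@]23C)cc1`, has methyl in place of methoxy on an aromatic carbon, para to a large group: methyl in place of methoxy on an aromatic carbon. Going by the values given here, only one measured step bears on this change: a number 0.31 log units higher from compound 1 to compound 2 (beyond the scatter). That step is modest, lies beyond the scatter and has methoxy as its incoming group. Among the compounds with values here, no measured step has methoxy leaving, so the support is indirect. An upward step of similar modest size is expected: a number 0.30 log units higher from compound 2 to compound 3 (within the scatter). The estimated value for compound 3 is 3.55, with an expected range from 3.25 to 3.85.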

Compound 3, partition coefficient: 3.64
Compound 3: the middle estimate sits 0.09 log units below what was measured; the measured number falls inside the stated range.
By their numbers in this assay, from the lowest: compound 1; then compound 2; then compound 3.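

In this assay, the place para to a large group now shows three substituents in one order, with methyl in place of methoxy giving a number 0.39 log units higher from compound 2 to compound 3 (beyond the scatter) on the shared core. Methyl in place of cyano gives a number 0.70 log units higher from compound 1 to compound 3 (beyond the scatter) as the widest span in the set, and each of the steps among these three compounds lies beyond the scatter. No measurement accompanies these numbers that could account for this order.

The compounds shown leave open where an amine, a carboxylic acid, a chlorine atom or a longer chain such as propyl would fall in this order at the same place. They also leave open whether methyl, methoxy and cyano keep this order on another aromatic carbon of the ring or on a different core.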